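Sodium channel type 3 series: ring-closed amide analogue

The source may report more compounds than this note shows. Statements on the series, on what has been measured and on what is new or still open speak of the compounds shown alone.

Measured compounds:
- compound 1 `O=C1NCCC1NCc1ccc(OCc2ccccc2F)cc1`: 126000 nM
- compound 2 `NC(=O)CNCc1ccc(OCc2ccccc2F)cc1`: 50100 nM

Both numbers come from an assay on HEK293 cells for inhibition of sodium channel protein type 3 subunit alpha (Homo sapiens), read by electrophysiology, with a stated time of 3.5 min; on this read-out lower numbers stand for stronger inhibition and higher numbers for weaker inhibition. Among the compounds with values here, compound 2 stands lowest of the two numbers; its nearest neighbour is compound 1, and the step of a 2.5-fold lower number from compound 1 to compound 2 (0.40 log units; beyond the scatter) is the only measured step so far, a modest one brought about by carbamoylmethyl in place of 2-oxopyrrolidin-3-yl on an amine nitrogen.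

Compound 3 `NC(=O)[C@@H]1CCCN1Cc1ccc(OCc2ccccc2F)cc1` is not yet measured. It differs from compound 2 by 2-carbamoylpyrrolidin-1-yl in place of (carbamoylmethyl)amino on a saturated chain carbon bound to an aromatic carbon. The change brings back one five-membered non-aromatic ring with 1 hetero atom while the primary amide of compound 2 is kept, so it sits between the two measured compounds in its make-up. Within the data shown here, the one step that bears on it, a 2.5-fold lower number from compound 1 to compound 2 (0.40 log units; beyond the scatter), was modest, and no step involving a 2-carbamoylpyrrolidin-1-yl group has been measured. A step of about that size or smaller, in either direction, is all that can be expected in this assay; the estimate for the step from compound 2 to compound 3 is a 1.3-fold higher number from compound 2 to compound 3 (0.10 log units; within the scatter), i.e. a number within the scatter of compound 2 or a little higher. Compound 3 is therefore estimated at 63000 nM, with a range from 20000 nM to 200000 nM.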

Compound 3, half-maximal inhibitory concentration: 79400 nM
Compound 3: middle estimate off by 1.3-fold (0.10 log units), on the low side, and the stated range covers the measured number.
By their numbers in this assay, from the lowest: compounds 2, 3 and 1 (each within the scatter of the next, the first and the last beyond it).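

In this assay the larger 2-carbamoylpyrrolidin-1-yl group, with 8 heavy atoms against 5 for (carbamoylmethyl)amino, one five-membered non-aromatic ring and 1 defined stereocentre, gives a 1.6-fold higher number from compound 2 to compound 3 (0.20 log units; within the scatter) and so stays within the scatter at this saturated chain carbon bound to an aromatic carbon. The comparison with the other ring-bearing compound gives a 1.6-fold lower number from compound 1 to compound 3 (0.20 log units; within the scatter) and also stays within the scatter, so compound 3 cannot be separated from either neighbour even though compound 1 and compound 2 lie beyond the scatter of each other. No measured evidence bears on the reason for these small steps.

A carboxylic acid or a nitrile in place of the primary amide of compound 3, or a six-membered piperidine ring in place of its pyrrolidine ring, could show whether this position can give a step beyond the scatter in either direction. The mirror-image form of compound 3 also remains open, so the compounds shown say nothing about the role of the defined stereocentre.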